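From Chloro to Trifluoromethoxy at the Limit of the Assay

The source may report more compounds than this note shows. Statements on the series, on what has been measured and on what is new or still open speak of the compounds shown alone.

Among the measured compounds shown here, in a functional assay on A549 cells (Homo sapiens) for antiproliferative activity, read by MTT assay, with a stated time of 72 h (a higher number here means a weaker inhibitor, a lower number a stronger inhibitor), compound 1 `COc1cc(-n2ncnc2-c2ccc(C)cc2)cc(OC)c1OC` gives 1100 nM, the only true number so far. Compound 2 `COc1cc(-n2ncnc2-c2ccc(Cl)cc2)cc(OC)c1OC` is reported only as a limit, > 10000 nM. Of the two values in hand, this is the limit of > 10000 nM in this assay, at which 1 of the 2 values shown sits, so compound 2 is bounded on one side only.

Compound 3 `COc1cc(-n2ncnc2-c2ccc(OC(F)(F)F)cc2)cc(OC)c1OC` carries trifluoromethoxy in place of chloro on an aromatic carbon, para to a large group (trifluoromethoxy in place of chloro on an aromatic carbon). For the measured compounds named here, one measured step bears on this change, made on the same carbon: chloro in place of methyl gave an at least 9.0-fold higher number from compound 1 to compound 2 (0.95 log units; beyond the scatter). That step lies beyond the scatter, so a swap at this carbon can cost a great deal in this assay, but it says nothing direct about trifluoromethoxy. With compound 2 at a limit, only a modest recovery toward a lower number is expected, and another limit is quite possible. The expected change is an at least 1.2-fold lower number from compound 2 to compound 3 (0.09 log units; that floor lies within the scatter). For compound 3 the estimated value is 8000 nM, with an expected range from 2500 nM to 25000 nM.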

Compound 3, half-maximal inhibitory concentration: > 10000 nM
Compound 3 gave a limit, no number (the forecaster's own chance of this, stated with the estimate: 55%); middle value at least 1.2-fold (0.09 log units) away from the limit.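

Compound 3 shows that the loss on leaving methyl is not confined to chloro. In this assay, trifluoromethoxy in place of methyl on the same aromatic carbon gives an at least 9.0-fold higher number from compound 1 to compound 3 (0.95 log units; beyond the scatter), so a second, larger group at this position also fails to keep the measurable activity of compound 1. Compound 2 and compound 3 both stand as limits, the step between them cannot be read, and no order of chloro and trifluoromethoxy can be stated; of the compounds shown, only the methyl compound has a true number, while the others share one boundary: the limit of > 10000 nM in this assay, at which 2 of the 3 values shown sit.

The compounds shown leave open what true values lie behind those two limits, and whether methyl is unusual at this carbon or is simply one of several groups that retain a measurable value. An ethyl group, a methoxy group or an amine on this aromatic carbon, set on the same shared core, would show whether any other group keeps a true number in this assay.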